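The compounds below may be only part of what the source reports. "The series", "measured", "known", "first", "only" and "open" are said of these compounds alone.

In a functional assay on CCRF-CEM cells (Homo sapiens) for cytotoxicity (on this read-out higher numbers stand for weaker inhibition and lower numbers for stronger inhibition), three compounds have been measured. Compound 1 `Cc1ccc(NC(=O)/C=C/C(=O)N2C/C(=C\c3ccc([N+](=O)[O-])cc3)C(=O)/C(=C/c3ccc([N+](=O)[O-])cc3)C2)cc1C` gives 700 nM, compound 3 `O=C(/C=C/C(=O)N1C/C(=C\c2ccc([N+](=O)[O-])cc2)C(=O)/C(=C/c2ccc([N+](=O)[O-])cc2)C1)Nc1ccccc1` gives 370 nM, and compound 2 `CC(=O)c1ccc(NC(=O)/C=C/C(=O)N2C/C(=C\c3ccccc3)C(=O)/C(=C/c3ccccc3)C2)cc1` gives 1700 nM. Compound 2 therefore stands highest of the three numbers, with compound 1 nearest and compound 3 furthest, both gaps beyond the scatter. Compound 4 `Cc1cccc(C)c1NC(=O)/C=C/C(=O)N1C/C(=C\c2ccccc2)C(=O)/C(=C/c2ccccc2)C1` is built from compound 2 by a single change: 2,6-dimethylphenyl in place of 4-acetylphenyl on an amide-type nitrogen. Going by the values given here, the only measured step at the same amide-type nitrogen is a 1.9-fold lower number from compound 1 to compound 3 (0.28 log units; within the scatter), which lies within the scatter, but it compares a phenyl with a 3,4-dimethylphenyl in a pair whose shared core differs from the core of compound 2. Among the compounds with values here, no measured step removes a 4-acetylphenyl, so how that group matters is unknown. A modest step at most is expected, leaning toward a lower number because compound 1 carrying a dimethylphenyl gives 700 nM. Compound 4 is expected to give about 1200 nM, in a range from 400 nM to 3600 nM. This means an expected step of a 1.4-fold lower number from compound 2 to compound 4 (0.15 log units; within the scatter).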

Compound 4, half-maximal inhibitory concentration: 7400 nM
The estimate for compound 4 lay 6.2-fold (0.79 log units) below the measured number; the measured number lies above the stated range.
By their numbers in this assay, from the lowest: compounds 3 and 1 (each within the scatter of the next); then compound 2; then compound 4.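

In this assay, the group on the amide-type nitrogen clearly matters on this core: 2,6-dimethylphenyl in place of 4-acetylphenyl gives a 4.4-fold higher number from compound 2 to compound 4 (0.64 log units; beyond the scatter), a shift beyond the usual scatter. Going by these compounds alone, the only earlier step at this nitrogen, a 1.9-fold lower number from compound 1 to compound 3 (0.28 log units; within the scatter), lay within the scatter and on a different core, so it showed no clear effect of changing this group. Nothing measured here explains the rise.

The swap removes the acetyl group and adds two methyl groups at once, so the compounds shown cannot tell which of these drives the step. Going by these compounds, it also remains open how this core would respond to a plain phenyl on the same nitrogen, or to a ring carrying an amine or a carboxylic acid.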